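Swapping the Ring on Compound 1's Side Chain

This account rests on a few compounds, and the source may have more. Where it says the series, first, only, none or still open, it means among the compounds named here.

- Compound 1 `CCN(Cc1ccc(OCCN2C(=O)CCC2=O)c(C)c1)C(CC(=O)O)c1ccc(Cl)cc1`: 3.9 nm/s
- Compound 2 `Cc1cc(CN(CC2CCCCC2)C(CC(=O)O)c2ccc(Cl)cc2)ccc1OCCN1C(=O)CCC1=O`: 83.9 nm/s
- Compound 3 `Cc1cc(CN(CCC(F)(F)F)C(CC(=O)O)c2ccc(Cl)cc2)ccc1OCCN1C(=O)CCC1=O`: "not determined" (no result reported)

Within the data shown here, in an ADME assay on Caco-2 cells (Homo sapiens) for permeability, read by LC-MS, with a stated time of 2 h (a lower number here means that the compound crosses the layer more slowly, a higher number that the compound crosses the layer faster), compound 1 has the lower of the only two numbers available, since compound 3 gave no number. Compound 4 `CCN(Cc1ccc(OCCn2c(=O)ccn(C)c2=O)c(C)c1)C(CC(=O)O)c1ccc(Cl)cc1` has not been measured yet. It keeps the core of compound 1 and differs in one place: a group of 9 heavy atoms (5 carbon, 2 nitrogen, 2 oxygen; one six-membered aromatic ring with 2 hetero atoms) in place of a group of 7 heavy atoms (4 carbon, 1 nitrogen, 2 oxygen; one five-membered non-aromatic ring with 1 hetero atom), on a saturated chain carbon, two bonds along the chain from an oxygen on an aromatic ring.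

Among the measured compounds shown here, the only measured step, a 22-fold higher number from compound 1 to compound 2 (1.33 log units; beyond the scatter), is large and lies beyond the scatter. That step replaces a methyl with a cyclohexyl on a saturated chain carbon bound to an amine nitrogen, which is a different part of the molecule. For the measured compounds named here, it therefore gives no direct guide to the new group, and no measured pair tests a change at this place. With no evidence for a direction, the expectation stays close to compound 1 at 3.9 nm/s, with a wide range. The expected step is a 1.0-fold higher number from compound 1 to compound 4 (0.01 log units; within the scatter), with no change beyond the scatter anticipated. Compound 4 is estimated at 4 nm/s, with an expected range of 1.5 nm/s to 12 nm/s.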

Compound 4, apparent permeability: 2.1 nm/s
For compound 4 the middle estimate is 1.9-fold (0.28 log units) above the measured one; measured number inside the range.
By their numbers in this assay, from the lowest: compounds 4 and 1 (each within the scatter of the next); then compound 2.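

Among these compounds, this is the first measured pair that tests the place on a saturated chain carbon, two bonds along the chain from an oxygen on an aromatic ring. In this assay, a six-membered aromatic ring with 2 hetero atoms in place of 2,5-dioxopyrrolidin-1-yl gives a 1.9-fold lower number from compound 1 to compound 4 (0.27 log units; within the scatter) and so the two compounds cannot be told apart, even though the entering group has more heavy atoms and more hydrogen-bond acceptors. Nothing measured here bears on the reason for this result.

As far as these compounds go, both groups seen at this place are rings, so it remains open whether an open-chain amine or a carboxylic acid there would keep the number within the scatter or move it beyond. Also open, from the compounds shown here alone, is whether the cyclohexyl change behind a 22-fold higher number from compound 1 to compound 2 (1.33 log units; beyond the scatter) would repeat with the new ring in place.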